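Smaller alkyl at the aromatic carbon: residence time outlook

The compounds below may be only part of what the source reports. "The series", "measured", "known", "first", "only" and "open" are said of these compounds alone.

Measured so far in an ADME assay on the whole organism (Macaca fascicularis); on this read-out lower numbers stand for a shorter-lived compound and higher numbers for a longer-lived compound:
compound 1 `Cc1ccc(-c2nc(=O)o[nH]2)c(-c2ccc([C@@H](C)N(CC3CC3)c3nc(C(=O)NS(=O)(=O)C4CC4)c(CC(C)C)s3)cc2)c1`: 4.9 h
compound 2 `Cc1ccc(-c2nc(=O)o[nH]2)c(-c2ccc([C@@H](C)N(CC3CC3)c3nc(C(=O)NS(=O)(=O)C4CC4)c(C4CCC4)s3)cc2)c1`: 5.7 h

Among the compounds with values here, compound 2 holds the higher of the two numbers in this assay, with compound 1 as its only neighbour and the gap within the scatter. Within the data shown here, the one measured step, a 1.2-fold higher number from compound 1 to compound 2 (0.07 log units; within the scatter), bears directly on the next move, since it also swapped the group on this aromatic carbon.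

Compound 3 `Cc1ccc(-c2nc(=O)o[nH]2)c(-c2ccc([C@@H](C)N(CC3CC3)c3nc(C(=O)NS(=O)(=O)C4CC4)c(C)s3)cc2)c1` follows from compound 2 by methyl in place of cyclobutyl on an aromatic carbon. Given that the earlier swap at the same position stayed within the scatter, no step beyond the scatter is expected in this assay in either direction. Compound 3 is estimated at 5 h (range 2.5 h to 10 h), an expected step of a 1.1-fold lower number from compound 2 to compound 3 (0.06 log units; within the scatter).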

Compound 3, mean residence time: 4.2 h
Compound 3: the middle estimate sits 1.2-fold (0.08 log units) above what was measured; low and high end bracket the measured number.
By their numbers in this assay, from the lowest: compounds 3, 1 and 2 (each within the scatter of the next).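

In this assay methyl in place of cyclobutyl stays within the scatter (a 1.4-fold lower number from compound 2 to compound 3 (0.13 log units; within the scatter)), and so does methyl against isobutyl (a 1.2-fold lower number from compound 1 to compound 3 (0.07 log units; within the scatter)). Across isobutyl, cyclobutyl and methyl, this aromatic carbon next to the ring sulfur therefore shows no step beyond the scatter, with or without the four-membered ring. No available evidence bears on why the numbers stay this close.

Still open, going by these compounds, is whether a group of another kind on this carbon, such as an amine or a carboxylic acid, would give a step beyond the scatter.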